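A few compounds are considered here, and "the series" means these few. Any claim that something is new, unique, unknown or untested is made for them only; others in the source may bear on it.

Measured so far:
- compound 1, `CC(=O)NCc1ccccc1C(=O)N[C@H](/C=C/S(=O)(=O)c1ccccc1)CCc1ccccc1`: 48000 nM
- compound 2, `O=C(NCc1ccccc1C(=O)N[C@H](/C=C(\F)S(=O)(=O)c1ccccc1)CCc1ccccc1)c1ccccc1`: 43000 nM

The two compounds that have been tested share one core, and both were examined in a toxicity assay on J774.1 cells (Mus musculus) for cytotoxicity, read by MTT assay, with a stated time of 48 h; on this read-out higher numbers stand for lower toxicity in this test and lower numbers for higher toxicity in this test. On this read-out compound 1 gives 48000 nM, the higher of the two numbers. Compound 2 gives 43000 nM, and the two values lie within the scatter of each other, so neither can be called the less toxic one.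

The next compound, compound 3, `O=C(O)c1cccc(C(=O)NCc2ccccc2C(=O)N[C@H](/C=C/S(=O)(=O)c2ccccc2)CCc2ccccc2)c1`, has not yet been tested. Its structure is that of compound 1 with one change: 3-carboxyphenyl in place of methyl on a carbonyl carbon. The acetyl group of compound 1 thus becomes a (3-carboxyphenyl)carbonyl group in compound 3.

Among the measured compounds shown here, no step between two measured compounds shows what such an exchange does in this assay, so the expectation rests on the two measured values alone. Both stand close together, and the change to compound 3 gives no reason to expect a step beyond the scatter in either direction. Compound 3 is therefore estimated at 55000 nM, with a range from 25000 nM to 120000 nM; this means an expected step of a 1.1-fold higher number from compound 1 to compound 3 (0.06 log units; within the scatter).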

Compound 3, half-maximal cytotoxic concentration: > 100000 nM
Compound 3: no number, only a limit (the forecaster's own chance of this, stated with the estimate: 20%); at least 1.8-fold (0.25 log units) between middle value and limit.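

In this assay compound 3 gives > 100000 nM, which is a limit of the assay and not a number. Even so, putting 3-carboxyphenyl in place of methyl on the carbonyl carbon gives an at least 2.0-fold higher number from compound 1 to compound 3 (0.31 log units; beyond the scatter), the first step beyond the scatter in this small set, and it shows that this place in the molecule can carry a far larger group, with an aromatic ring and a carboxylic acid, without any rise in toxicity in this test. The true size of the step stays hidden, since the reading stops at a ceiling, and only its lower bound is known: the limit of > 100000 nM in this assay, at which 1 of the 3 values shown sits.

As far as these compounds go, what remains open is which part of the new group goes with the higher number, the ring or the carboxylic acid, since compound 2 also has a ring on this carbonyl but differs from compound 1 in a second place as well. A methyl ester in place of the carboxylic acid, or an amine on the same ring, would help to separate these two parts, and a value below the limit would be needed to put a size on any such change.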